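Sulfonylmethyl thiazoline to oxazoline swap on two cores

This account rests on a few compounds, and the source may have more. Where it says the series, first, only, none or still open, it means among the compounds named here.

Compound 1 `O=S(=O)(CC1=NCCS1)C1C(c2ccccc2)=NOC1c1ccccc1` is reported in a functional assay, read by Griess assay, with a stated time of 150 min, tested at 75 ug/mL (on this read-out lower numbers stand for a weaker effect and higher numbers for a stronger effect at the one concentration tested), as "not active" (no number reported), with no number given. Compound 2 `Cc1ccc(C2CNN=C2S(=O)(=O)CC2=NCCS2)cc1` gives 48.6% in this assay, and compound 3 `Cc1ccc(C2CNN=C2S(=O)(=O)CC2=NCCO2)cc1` gives 49.7%. The change between them, (a group of 5 heavy atoms (3 carbon, 1 nitrogen, 1 oxygen; one five-membered non-aromatic ring with 2 hetero atoms) in place of a group of 5 heavy atoms (3 carbon, 1 nitrogen, 1 sulfur; one five-membered non-aromatic ring with 2 hetero atoms), on a saturated chain carbon bound to a sulfonyl sulfur), gives the step of a number 1.1 percentage points higher from compound 2 to compound 3 (within the scatter). The difference between the core of compound 1 and that of compound 2 is not broken down here. Compound 4 `O=S(=O)(CC1=NCCO1)C1C(c2ccccc2)=NOC1c1ccccc1` carries the same change on the core of compound 1, (a group of 5 heavy atoms (3 carbon, 1 nitrogen, 1 oxygen; one five-membered non-aromatic ring with 2 hetero atoms) in place of a group of 5 heavy atoms (3 carbon, 1 nitrogen, 1 sulfur; one five-membered non-aromatic ring with 2 hetero atoms), on a saturated chain carbon bound to a sulfonyl sulfur), at the same place as before. Since the step from compound 2 to compound 3 stayed within the scatter and compound 1 is reported as "not active" (no number reported), compound 4 is expected to remain close to inactive in this assay, with an estimated value of 8% and a range of 0% to 25%; the report may again give no number.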

Compound 4, a percentage reported as activity, at one concentration (the size of the read-out at that concentration, not a potency): 57.2%
The estimate for compound 4 lay 49.2 percentage points below the measured number; measured number outside the range, above it.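

In this assay, within the data shown here, compound 1 is reported as "not active" (no number reported) and compound 4 gives 57.2%, so no step between them can be read. On these data alone, the size of this change on the core of compound 1 stays open. No evidence on hand bears on the result.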